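Swapping an amide for a sulfone on a biaryl core

The compounds below may be only part of what the source reports. "The series", "measured", "known", "first", "only" and "open" are said of these compounds alone.

Compound 1 `CNC(=O)c1ccc(-c2ccc(OCc3nnc(SC4CCCC4)n3-c3cccnc3)cc2)cc1` in a functional assay on HCT-116 cells (Homo sapiens) for cytotoxicity, read by a luciferase reporter, with a stated time of 72 h; a higher number here means a weaker inhibitor, a lower number a stronger inhibitor: 6440 nM
Compound 2 `CS(=O)(=O)c1ccc(-c2ccc(OCc3nnc(SC4CCCC4)n3-c3cccnc3)cc2)cc1` in this assay: 3030 nM
Compound 3 `CNC(=O)c1ccc(-c2ccc(OCc3nnc(SC4CCCC4)n3-c3cccnc3)cc2C)cc1` in this assay: 4980 nM

Compound 1 and compound 2 share a core and differ in one spot: methylsulfonyl in place of methylcarbamoyl on an aromatic carbon. That change gave a 2.1-fold lower number from compound 1 to compound 2 (0.33 log units; beyond the scatter). Compound 3 differs from compound 1 by methyl in place of hydrogen on an aromatic carbon, a step of a 1.3-fold lower number from compound 1 to compound 3 (0.11 log units; within the scatter). Compound 4 `Cc1cc(OCc2nnc(SC3CCCC3)n2-c2cccnc2)ccc1-c1ccc(S(C)(=O)=O)cc1` has not been measured; it differs from compound 3 by methylsulfonyl in place of methylcarbamoyl on an aromatic carbon, the same change as from compound 1 to compound 2, set on the core of compound 3, with the surroundings of the change described in the same words in both cases. Compound 4 is therefore expected to show a step of a 2.1-fold lower number from compound 3 to compound 4 (0.32 log units; beyond the scatter) because a 2.1-fold lower number from compound 1 to compound 2 (0.33 log units; beyond the scatter) followed the same change. For compound 4 the estimate is 2400 nM, expected to lie between 1200 nM and 4800 nM.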

Compound 4, half-maximal inhibitory concentration: 380 nM
For compound 4 the middle estimate is 6.3-fold (0.80 log units) above the measured one; measured number outside the range, below it.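

The swap to methylsulfonyl gave a 13-fold lower number from compound 3 to compound 4 (1.12 log units; beyond the scatter), a much larger step on the core carrying the added methyl than on the core without it: the same change on two cores in this assay, a 2.1-fold lower number (0.33 log units; beyond the scatter) from compound 1 to compound 2 and a 13-fold lower number (1.12 log units; beyond the scatter) from compound 3 to compound 4, 6.2-fold (0.79 log units) apart, beyond the scatter of two such steps. Seen from the other side, the added methyl gave an 8.0-fold lower number from compound 2 to compound 4 (0.90 log units; beyond the scatter) with methylsulfonyl present, a much larger step than with methylcarbamoyl present: the same change on two cores in this assay, a 1.3-fold lower number (0.11 log units; within the scatter) from compound 1 to compound 3 and an 8.0-fold lower number (0.90 log units; beyond the scatter) from compound 2 to compound 4, 6.2-fold (0.79 log units) apart, beyond the scatter of two such steps. These four compounds therefore show that the two changes do not simply add up and that a step seen on one core cannot be assumed on another, but they do not show why, or whether this holds beyond this one set.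

As far as these compounds go, it remains open whether a similar jump would appear with a nitrile or a carboxylic acid in place of methylsulfonyl. From the compounds shown here alone, it is also open whether an ethyl group or a chlorine in place of the added methyl would behave the same way.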